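This account rests on a few compounds, and the source may have more. Where it says the series, first, only, none or still open, it means among the compounds named here.

Notes on the spiro-piperidine amide series, read against an ADME assay on microsomes from liver (Mus musculus) for metabolic stability, read by LC-MS, with a stated time of 40 min, tested at 0.5 uM; on this read-out lower numbers stand for slow clearance and higher numbers for fast clearance.

Compound 1 `O=C(Nc1cccc(S(=O)(=O)N2CCCC2)c1)c1cccnc1N1CCC2(CC1)CC2` is the reference point of the set. In this assay compound 1 returns only a limit, > 399 mL.min-1.g-1, not a number. Two companions stand nearby. Among the measured compounds shown here, compound 2 `CC(C)(C)NS(=O)(=O)c1cccc(NC(=O)c2ncc(NS(C)(=O)=O)nc2N2CCC3(CC2)CC3)n1` is the one member with a resolved value, giving 64 mL.min-1.g-1 in this assay. Compound 3 `CC(C)(O)CNc1ccc(C(=O)Nc2cccc(S(=O)(=O)C3CCCC3)n2)c(N2CCC3(CC2)CC3)c1` also returns a limit in this assay, > 399 mL.min-1.g-1, and not a number. Across the three, compound 1 therefore sits at the ceiling of the read-out, shared with compound 3, while compound 2 alone falls well under it; with two of three values at the limit, (the limit of > 399 mL.min-1.g-1 in this assay, at which 2 of the 3 values shown sit), the spread in this set is only partly resolved.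

The next compound, compound 4 `CC(C)S(=O)(=O)c1cccc(NC(=O)c2cccnc2N2CCC3(CC2)CC3)c1`, differs from compound 1 in a single place: isopropyl in place of pyrrolidin-1-yl on a sulfonyl sulfur. For the measured compounds named here, no measured pair in the set isolates this change, so no step size can be read off directly; the expectation is that compound 4 stays fast-clearing, with the step of an at least 1.3-fold lower number from compound 1 to compound 4 (0.12 log units; that floor lies within the scatter) expected to fall within the scatter or to be a modest easing at most. Compound 4 is estimated at 300 mL.min-1.g-1, within 120 mL.min-1.g-1 to 450 mL.min-1.g-1, with a real chance that it again returns only the limit.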

Compound 4, intrinsic clearance in microsomes: > 399 mL.min-1.g-1
Compound 4 was reported as a limit (the forecaster's own chance of this, stated with the estimate: 45%); middle value at least 1.3-fold (0.12 log units) away from the limit.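

Compound 1 and compound 4 both return only a limit in this assay, so no step can be read for isopropyl in place of pyrrolidin-1-yl on a sulfonyl sulfur: the limit of > 399 mL.min-1.g-1 in this assay, at which 3 of the 4 values shown sit.

The compounds shown leave open whether this change on the sulfonyl sulfur alters clearance at all, and in which direction.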